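Swapping methoxy for bromo on a weak compound

A few compounds are considered here, and "the series" means these few. Any claim that something is new, unique, unknown or untested is made for them only; others in the source may bear on it.

Within the data shown here, only two compounds have numbers so far, and compound 1 (`COc1ccc(N2CCCC2)c(C(=O)Nc2ccc(CNC(=O)OCc3cccnc3)cc2)c1`) sits at the weak end. In a functional assay on HGC-27 cells (Homo sapiens) for inhibition, read by MTT assay, with a stated time of 72 h (a higher number here means a weaker inhibitor, a lower number a stronger inhibitor), compound 1 gives 138000 nM and so holds the higher of the two numbers. Compound 2 (`Cc1cccc(C(=O)Nc2ccc(CNC(=O)OCc3cccnc3)cc2)c1N1CCCC1`) gives 1030 nM in this assay and that gap lies well beyond the usual scatter.

Compound 3 (`O=C(NCc1ccc(NC(=O)c2cc(Br)ccc2N2CCCC2)cc1)OCc1cccnc1`) has not yet been measured. It differs from compound 1 in a single place: bromo in place of methoxy on an aromatic carbon with bromo in place of methoxy on an aromatic carbon, para to a pyrrolidin-1-yl group.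

Among the measured compounds shown here, no measured pair isolates this swap, so the expectation rests on thin ground. Compound 2 carries no methoxy and reaches 1030 nM in this test, which suggests that the number of compound 1 need not hold once the methoxy is gone. The expected change is a 35-fold lower number from compound 1 to compound 3 (1.54 log units; beyond the scatter) and that would be a clear move toward stronger inhibition, beyond the scatter. The estimated value for compound 3 is 4000 nM within an expected range of 600 nM to 30000 nM in this assay once it is tested.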

Compound 3, half-maximal inhibitory concentration: 640 nM
The estimate for compound 3 lay 6.3-fold (0.80 log units) above the measured number; the measured number falls inside the stated range.
By their numbers in this assay, from the lowest: compounds 3 and 2 (each within the scatter of the next); then compound 1.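

In this assay, among these compounds, bromo in place of methoxy on this aromatic carbon, para to a pyrrolidin-1-yl group, gives a 220-fold lower number from compound 1 to compound 3 (2.33 log units; beyond the scatter) and so provides the first direct reading of this position, as no earlier pair differed in only one place. The edit itself is small: methoxy takes away 2 heavy atoms and 1 hydrogen-bond acceptor, bromo brings 1 heavy atom and no hydrogen-bond acceptor, and neither group adds a ring or a net charge. This single position therefore has a large effect on the number in this test, but no measurement at hand shows what lies behind the step.

As far as these compounds go, with only methoxy and bromo compared here, it remains open whether the gain comes from having bromo or simply from losing methoxy, and a chloro group, a nitrile or an amine on the same carbon would help separate those two readings. From the compounds shown here alone, it is also open whether the same swap would give a step of similar size on a different core or in another cell line.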